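The source may hold more compounds than are shown below. What is called first, only, known or untested is meant among the compounds shown, and "the series" means these compounds.

In a functional assay on HCT-116 cells (Homo sapiens) for cytotoxicity, read by MTT assay, with a stated time of 72 h (a higher number here means a weaker inhibitor, a lower number a stronger inhibitor), compound 1 `Cc1ccc(S(=O)(=O)c2nc3ccccc3nc2N2CCCC2)cc1` sits at the limit > 50000 nM and so gives a limit and not a number. Among the compounds with values here, compound 2 `O=S(=O)(c1ccccc1)c1nc2ccccc2nc1N1CCc2ccccc2C1` gives 18700 nM as the only number so far. Compound 3 `Cc1ccc(S(=O)(=O)c2nc3ccccc3nc2N2CCc3ccccc3C2)cc1` differs from compound 2 by methyl in place of hydrogen on an aromatic carbon with methyl in place of hydrogen on an aromatic carbon, para to a large group. Within the data shown here, no measured step in this assay covers this change, so no shift beyond the scatter is expected, and neither direction is favoured. The estimated step of a 1.0-fold lower number from compound 2 to compound 3 (0.02 log units; within the scatter) is small. Compound 3 is expected at 18000 nM with an estimated range from 7000 nM to 45000 nM as its upper end.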

Compound 3, half-maximal inhibitory concentration: 39000 nM
The estimate for compound 3 lay 2.2-fold (0.34 log units) below the measured number; low and high end bracket the measured number.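

In this assay, the aryl ring on the sulfonyl group proves sensitive to even a small addition: methyl in place of hydrogen on an aromatic carbon gives a 2.1-fold higher number from compound 2 to compound 3 (0.32 log units; beyond the scatter), a loss and not a gain. 1,2,3,4-tetrahydroisoquinolin-2-yl in place of pyrrolidin-1-yl gives an at least 1.2-fold lower number from compound 1 to compound 3 (0.10 log units; that floor lies within the scatter), a floor within the scatter, so the size of this change stays unset: the limit of > 50000 nM in this assay, at which 1 of the 3 values shown sits.

Open, on these data alone, is how a methoxy group, a chlorine atom or a carboxylic acid at the same place would compare with the phenyl of compound 2. Also open, as far as these compounds go, is whether pyrrolidin-1-yl on the unsubstituted phenylsulfonyl gives a number at all.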